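A few compounds are considered here, and "the series" means these few. Any claim that something is new, unique, unknown or untested is made for them only; others in the source may bear on it.

Measured so far:
compound 1 `Cn1c(=O)c(S(=O)(=O)c2ccc(Cl)cc2)cc2cnc(Nc3cnc4ccccc4c3)nc21` gives 15000 nM in a functional assay on K562 cells (Homo sapiens) for inhibition, read by trypan blue exclusion, with a stated time of 72 h; on this read-out lower numbers stand for stronger inhibition and higher numbers for weaker inhibition;
compound 2 `COc1ccc(Nc2ncc3cc(S(=O)(=O)c4ccc(Cl)cc4)c(=O)n(C)c3n2)cc1` gives 15000 nM;
compound 3 `Cn1c(=O)c(S(=O)(=O)c2ccccc2)cc2cnc(Nc3cnc4[nH]ccc4c3)nc21` gives 5000 nM.

Compound 3 therefore shows the lowest number of the three, with both other compounds standing beyond the scatter above it. Compound 4 `Cn1c(=O)c(S(=O)(=O)c2ccc(Cl)cc2)cc2cnc(Nc3cnc4[nH]ccc4c3)nc21` differs from compound 3 by chloro in place of hydrogen on an aromatic carbon. Going by the values given here, no measured step changes this part of the molecule: the only step, no change at the digits printed from compound 1 to compound 2 (within the scatter), concerns the group on the amine nitrogen. Compounds 1 and 2 already carry the (4-chlorophenyl)sulfonyl group but also differ from compound 3 elsewhere, so their values do not isolate the chloro. Compound 4 is therefore expected to stay close to compound 3, an estimated step of no change at the digits printed from compound 3 to compound 4 (within the scatter), giving an estimate of 5000 nM with a range from 2000 nM to 15000 nM.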

Compound 4, half-maximal inhibitory concentration: 5000 nM
Beside the measured number, compound 4's estimate shows no gap at the digits printed; low and high end bracket the measured number.
By their numbers in this assay, from the lowest: compounds 3 and 4 (each within the scatter of the next); then compounds 1 and 2 (each within the scatter of the next).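

In this assay, going by these compounds alone, chloro in place of hydrogen on the phenyl ring of the phenylsulfonyl group gives no change at the digits printed from compound 3 to compound 4 (within the scatter) and this is the first direct reading of that change. With the (4-chlorophenyl)sulfonyl group held fixed, changing only the group on the amine nitrogen gives a 3.0-fold lower number from compound 2 to compound 4 (0.48 log units; beyond the scatter) and a 3.0-fold lower number from compound 1 to compound 4 (0.48 log units; beyond the scatter) so among these compounds the number follows that group and not the chloro.

On these data alone, whether a methoxy group or an amine in the chloro's place would shift the number remains open. Nothing available explains either result.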